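Swapping the aryl group on the anilino nitrogen

The source may hold more compounds than are shown below. What is called first, only, known or untested is meant among the compounds shown, and "the series" means these compounds.

Of the compounds shown here, two from this series have been measured. Compound 1 `Cc1ccc(NC2=CC(=O)c3nc4n(c3C2=O)[C@H]2OC[C@@H](O)[C@H]2OC4)cc1C` gives 2690 nM in a functional assay on HeLa cells (Homo sapiens) for inhibition, read by sulforhodamine B assay; a lower number here means a stronger inhibitor, a higher number a weaker inhibitor. Compound 2 `O=C1C=C(Nc2cccc(Cl)c2)C(=O)c2c1nc1n2[C@H]2OC[C@@H](O)[C@H]2OC1` gives 6040 nM in the same assay, and stands as the higher of the two numbers shown, so it is the weaker of the pair. Among the compounds with values here, the one measured step, a 2.2-fold higher number from compound 1 to compound 2 (0.35 log units; beyond the scatter), moved the number up by a modest amount. Compound 3 `COc1ccc(NC2=CC(=O)c3nc4n(c3C2=O)[C@H]2OC[C@@H](O)[C@H]2OC4)cc1` differs from compound 2 in one place: 4-methoxyphenyl in place of 3-chlorophenyl on an amine nitrogen. Within the data shown here, no measured step involves a methoxy group, so the only guide is that exchanging the aryl ring on this nitrogen in the single known step shifted the number by just over the scatter. A change of similar size, in either direction, is therefore the most that the data support. Compound 3 is expected to give about 4000 nM, with a range from 1500 nM to 10000 nM, an estimated step of a 1.5-fold lower number from compound 2 to compound 3 (0.18 log units; within the scatter).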

Compound 3, half-maximal inhibitory concentration: 4780 nM
Compound 3: middle estimate off by 1.2-fold (0.08 log units), on the low side; the measured number falls inside the stated range.
By their numbers in this assay, from the lowest: compounds 1, 3 and 2 (each within the scatter of the next, the first and the last beyond it).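

Putting 4-methoxyphenyl in place of 3-chlorophenyl on the amine nitrogen gives a 1.3-fold lower number from compound 2 to compound 3 (0.10 log units; within the scatter), and putting it in place of 3,4-dimethylphenyl gives a 1.8-fold higher number from compound 1 to compound 3 (0.25 log units; within the scatter). In this assay, compound 3 therefore cannot be told apart from either compound 1 or compound 2, although those two differ from each other by more than the scatter. Nothing available accounts for these small differences.

The compounds shown leave open whether a group of another kind on this nitrogen, such as a pyridine ring or a plain alkyl chain, would keep the number in this range. Also open, from the compounds shown here alone, is how a carboxylic acid or an amine on the phenyl ring would affect it.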